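The compounds below may be only part of what the source reports. "The series", "measured", "known", "first", "only" and "open" are said of these compounds alone.

Measured in an ADME assay on MT4 cells (Homo sapiens) for cytotoxicity, read by MTT assay, with a stated time of 96 h; on this read-out lower numbers stand for higher toxicity in this test and higher numbers for lower toxicity in this test:
- compound 1 `O=C(CN1CCCCC1)Nc1ccc(-c2nc3cc(C(F)(F)F)ccc3[nH]2)cc1`: 6000 nM
- compound 2 `COc1ccc(-c2nc3cc(C(F)(F)F)ccc3[nH]2)c(N)c1`: 5000 nM
- compound 3 `CCN(CC)CC(=O)Nc1ccc(-c2nc3cc(C(F)(F)F)ccc3n2C)cc1`: 9000 nM

Compound 3 has the largest number of the three, but its gap to compound 1, the nearest, and its gap to compound 2, the furthest, both fall within the scatter, so the three cannot be told apart on these data.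

Compound 4 `Cn1c(-c2ccc(NC(=O)CN3CCCCC3)cc2)nc2cc(C(F)(F)F)ccc21` is the next compound to be run in this assay. It differs from compound 3 in one place: piperidin-1-yl in place of diethylamino on a saturated chain carbon bound to a carbonyl carbon. Among the measured compounds shown here, no step between measured compounds bears on this change. A step of no size beyond the scatter is expected, as no change at the digits printed from compound 3 to compound 4 (within the scatter). Compound 4 is estimated at 9000 nM, within a range from 4000 nM to 20000 nM.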

Compound 4, half-maximal cytotoxic concentration: 9000 nM
Compound 4: the middle estimate sits on the measured number at the digits printed, and the stated range covers the measured number.
By their numbers in this assay, from the lowest: compounds 2, 1, 3 and 4 (each within the scatter of the next).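

In this assay, among the compounds shown here, piperidin-1-yl in place of diethylamino on a saturated chain carbon bound to a carbonyl carbon gives no change at the digits printed from compound 3 to compound 4 (within the scatter) as the first direct reading of this change. Methyl in place of hydrogen on an aromatic nitrogen gives a 1.5-fold higher number from compound 1 to compound 4 (0.18 log units; within the scatter) with piperidin-1-yl kept, so neither change moves the number beyond the scatter. Nothing available explains these small steps.

Still open, on these data alone, is whether morpholin-4-yl or dimethylamino on that saturated chain carbon would also stay within the scatter. The same question holds for ethyl in place of methyl on the aromatic nitrogen.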